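The source may hold more compounds than are shown below. What is called first, only, known or untested is meant among the compounds shown, and "the series" means these compounds.

Working notes on the series. Compound 1 `COc1ccc(OC)c(-c2cc(-c3ccccc3)nn2-c2ccc(S(N)(=O)=O)cc2)c1` gives 43700 nM in a functional assay on cells (Cancer cell lines, Homo sapiens) for cytotoxicity, read by sulforhodamine B assay, with a stated time of 48 h; a higher number here means a weaker inhibitor of growth, a lower number a stronger inhibitor of growth. Compound 2 `COc1ccc(OC)c(-c2cc(-c3ccccc3)nn2-c2ccc(S(=O)(=O)NC(C)=O)cc2)c1` gives 50700 nM, and compound 3 `COc1ccc(OC)c(-c2cc(-c3ccc(Cl)cc3)nn2-c2ccc(S(=O)(=O)NC(C)=O)cc2)c1` gives 67100 nM. Compound 2 thus stands second highest of the three numbers, with compound 1 and compound 3 on either side of it; the step of a 1.2-fold higher number from compound 1 to compound 2 (0.06 log units; within the scatter) and the step of a 1.3-fold higher number from compound 2 to compound 3 (0.12 log units; within the scatter) both stay within the scatter, so no ordering among the three can be claimed.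

Compound 4 `CC(=O)NS(=O)(=O)c1ccc(-n2nc(-c3ccccc3)cc2C2=CC(=O)C=CC2=O)cc1` differs from compound 2 in one place: a group of 8 heavy atoms (6 carbon, 2 oxygen; one six-membered non-aromatic ring of carbon only) in place of a group of 10 heavy atoms (8 carbon, 2 oxygen; one six-membered aromatic ring of carbon only), on an aromatic carbon. Neither measured step touches this position; the acetyl step and the chloro step each concern another part of the molecule and each was small. Within the data shown here, there is therefore no measured step that bears on this change, and the data give no direction for it. The expectation is accordingly centred near compound 2, with a wide range to cover an unseen kind of change, and the step of a 1.3-fold lower number from compound 2 to compound 4 (0.10 log units; within the scatter) is estimated as none beyond the scatter. For compound 4 the estimated value in this assay is 40000 nM, expected to fall between 8000 nM and 150000 nM.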

Compound 4, concentration for total growth inhibition: 100000 nM
Compound 4: the middle estimate sits 2.5-fold (0.40 log units) below what was measured; low and high end bracket the measured number.
By their numbers in this assay, from the lowest: compounds 1, 2, 3 and 4 (each within the scatter of the next, the first and the last beyond it).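

In this assay, among these compounds, the first reading at this position, on the aromatic carbon of the five-membered aromatic ring, gives a 2.0-fold higher number from compound 2 to compound 4 (0.29 log units; within the scatter) on exchanging 2,5-dimethoxyphenyl for the six-membered non-aromatic ring of carbon only. An aromatic ring bearing two methoxy groups is therefore not required here to keep the number within the scatter of compound 2, and the non-aromatic ring with its 4 double bonds outside aromatic rings is accepted at this place. No measurement available bears on why this step is as it is.

Going by these compounds, whether an amine, a carboxylic acid or a longer chain at this position would stay equally close to compound 2 remains open. Also open, on these data alone, is how the non-aromatic ring reads alongside a chloro on the phenyl group or a hydrogen in place of the acetyl on the sulfonamide nitrogen.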